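The source may hold more compounds than are shown below. What is called first, only, known or untested is meant among the compounds shown, and "the series" means these compounds.

Working notes on the series. Compound 1 `Cc1cn([C@@H]2C[C@H](O)[C@@H](CNC(=O)Nc3ccc(Br)cc3)O2)c(=O)[nH]c1=O` is tested in an ADME assay on MRC5 cells (Homo sapiens) for cytotoxicity (a higher number here means that more compound is tolerated, a lower number that less compound is tolerated), where compound 1 gives > 50000 nM, which is a limit of the assay and not a number. Compound 2 `Cc1cn([C@@H]2C[C@H](O)[C@@H](CNC(=S)Nc3ccc(Cl)c(C(F)(F)F)c3)O2)c(=O)[nH]c1=O` in this assay gives > 50000 nM, likewise a limit. Compound 3 `Cc1cn([C@@H]2C[C@H](O)[C@@H](CNC(=O)Nc3cccc(COc4ccccc4)c3)O2)c(=O)[nH]c1=O` in this assay gives > 50000 nM, again a limit. Compound 1 therefore stands at the limit of > 50000 nM in this assay, at which 3 of the 3 values shown sit. Among the compounds with values here, no measured pair differs in one place, so no step size is known from the data. Compound 4 `Cc1ccc2nc(-c3ccc(NC(=O)NC[C@H]4O[C@H](n5cc(C)c(=O)[nH]c5=O)C[C@@H]4O)cc3)sc2c1` is not yet measured; it differs from compound 1 as follows: 6-methyl-1,3-benzothiazol-2-yl in place of bromo on an aromatic carbon. The step of an at least 1.2-fold lower number from compound 1 to compound 4 (0.09 log units; that floor lies within the scatter) is expected to be small, if anything toward less compound tolerated, and not beyond the usual scatter. Compound 4 is accordingly estimated at 40000 nM, with a range from 10000 nM to 100000 nM, and a fair chance that only a limit is reported.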

Compound 4, half-maximal cytotoxic concentration: > 50000 nM
Compound 4: no number, only a limit; the forecaster's own chance of this, stated with the estimate: 55%; at least 1.2-fold (0.09 log units) between middle value and limit.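

Within the data shown here, no step from compound 1 to compound 4 can be read in this assay, since each gives only a limit of the assay and not a number: the limit of > 50000 nM in this assay, at which 4 of the 4 values shown sit. The compounds shown leave open whether 6-methyl-1,3-benzothiazol-2-yl in place of bromo changes the tolerated concentration at all.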